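The source may hold more compounds than are shown below. What is called first, only, known or untested is meant among the compounds shown, and "the series" means these compounds.

Measured so far:
- compound 1, `CC(C)OC(=O)N1CCC(Oc2ncnc3c2CCN3c2ccc(S(C)(=O)=O)cc2F)CC1`: 50.1 nM
- compound 2, `CC(C)OC(=O)N1CCC(Oc2ncnc3c2CCN3c2ccc(C#N)cc2F)CC1`: 63.1 nM
- compound 3, `CC(C)OC(=O)N1CCC(Oc2ncnc3c2CCN3c2ccc(-c3nccs3)cc2F)CC1`: 79.4 nM

All three share one core and differ only in the group on the aromatic carbon that sits para to the large group. In a functional assay on CHO-K1 cells for agonist activity at Glucose-dependent insulinotropic receptor (Homo sapiens), read by a luciferase reporter, with a stated time of 5 h (on this read-out lower numbers stand for an effect already at smaller amounts and higher numbers for an effect only at larger amounts of compound), compound 3 gives the highest of the three numbers, but the steps leading to it, a 1.6-fold higher number from compound 1 to compound 3 (0.20 log units; within the scatter) and a 1.3-fold higher number from compound 2 to compound 3 (0.10 log units; within the scatter), both lie within the scatter, so the three compounds cannot be told apart on this read-out.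

Compound 4, `CC(C)OC(=O)N1CCC(Oc2ncnc3c2CCN3c2ccc(-c3cccn3C)cc2F)CC1`, carries the next change at the same place: 1-methyl-1H-pyrrol-2-yl in place of 1,3-thiazol-2-yl on an aromatic carbon. This is again a swap of one aromatic group for another at that aromatic carbon. Within the data shown here, the steps that bear on it are the three swaps already measured, a 1.3-fold higher number from compound 1 to compound 2 (0.10 log units; within the scatter), a 1.6-fold higher number from compound 1 to compound 3 (0.20 log units; within the scatter) and a 1.3-fold higher number from compound 2 to compound 3 (0.10 log units; within the scatter), none of which moved the number beyond the scatter. On that basis no step beyond the scatter is expected in this assay, in either direction. Compound 4 is expected to give about 100 nM, between 40 nM and 300 nM. This estimate amounts to an expected 1.3-fold higher number from compound 3 to compound 4 (0.10 log units; within the scatter).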

Compound 4, half-maximal effective concentration: 158 nM
Compound 4: middle estimate off by 1.6-fold (0.20 log units), on the low side; low and high end bracket the measured number.
By their numbers in this assay, from the lowest: compounds 1, 2, 3 and 4 (each within the scatter of the next, the first and the last beyond it).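

In this assay this position now shows steps beyond the scatter, with a 2.5-fold higher number from compound 2 to compound 4 (0.40 log units; beyond the scatter) and a 3.2-fold higher number from compound 1 to compound 4 (0.50 log units; beyond the scatter) when 1-methyl-1H-pyrrol-2-yl replaces cyano and methylsulfonyl, both modest in size. Putting the same group in place of 1,3-thiazol-2-yl gives a 2.0-fold higher number from compound 3 to compound 4 (0.30 log units; within the scatter) and stays within the scatter, so this swap of one five-membered aromatic ring for another cannot be read as a real change. The groups at this aromatic carbon are therefore no longer all alike on this read-out, but nothing available explains what in the 1-methyl-1H-pyrrol-2-yl group lies behind these steps.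

Going by these compounds, it remains open whether the methyl on the pyrrole nitrogen matters, which the plain 1H-pyrrol-2-yl group could test. On these data alone, how an amine or a carboxylic acid at this aromatic carbon would compare also remains open.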